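Replacing cyclopropyl by an aryl group on the shared core

The source may report more compounds than this note shows. Statements on the series, on what has been measured and on what is new or still open speak of the compounds shown alone.

The shared core of compound 1 `C=CC(=O)Nc1cc(Nc2ncc(Cl)c(Nc3ccc(F)c(Cl)c3)n2)c(OC)cc1N1CCN(C)CC1` carries, on a nitrogen on an aromatic ring, the group that is varied across the series. In a functional assay on NCI-H1975 cells (Homo sapiens) for inhibition, read by CellTiter-Glo, with a stated time of 72 h (on this read-out higher numbers stand for weaker inhibition of growth and lower numbers for stronger inhibition of growth), compound 1 gives 100 nM. Compound 2 `C=CC(=O)Nc1cc(Nc2ncc(Cl)c(NCc3cccs3)n2)c(OC)cc1N1CCN(C)CC1` gives 220 nM in this assay. Compound 3 `C=CC(=O)Nc1cc(Nc2ncc(Cl)c(NC3CC3)n2)c(OC)cc1N1CCN(C)CC1` reports only a limit of the assay, > 10000 nM in this assay, so for compound 3 no number exists; it sits at the limit of > 10000 nM in this assay, at which 1 of the 3 values shown sits, and stands weakest among the three measured compounds. The measured steps to it are large: an at least 100-fold higher number from compound 1 to compound 3 (2.00 log units; beyond the scatter) and an at least 45-fold higher number from compound 2 to compound 3 (1.65 log units; beyond the scatter), while the step between the two aryl-type groups is only modest, a 2.2-fold higher number from compound 1 to compound 2 (0.34 log units; beyond the scatter).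

Compound 4 `C=CC(=O)Nc1cc(Nc2ncc(Cl)c(Nc3ccccc3S(=O)(=O)N(C)C)n2)c(OC)cc1N1CCN(C)CC1` is the next member, to be measured in this assay. The change from compound 3 is 2-(dimethylsulfamoyl)phenyl in place of cyclopropyl on a nitrogen on an aromatic ring. This reverses the direction of the measured steps into compound 3: the cyclopropyl group that leaves is the one tied to the loss of growth inhibition, and the group that enters is a six-membered aromatic ring, as in compound 1. A large recovery is therefore expected, an at least 66-fold lower number from compound 3 to compound 4 (1.82 log units; beyond the scatter), bringing compound 4 toward the region of compound 1 and compound 2. For compound 4 the estimate is 150 nM in this assay, with a range from 40 nM to 700 nM.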

Compound 4, concentration for 50% growth inhibition: 31 nM
Compound 4: middle estimate off by 4.8-fold (0.68 log units), on the high side, outside the stated range (below it).
By their numbers in this assay, from the lowest: compound 4; then compound 1; then compound 2. At a limit, above all of these: compound 3.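

Compound 4 now has the lowest number of the four in this assay (a 3.2-fold lower number from compound 1 to compound 4 (0.51 log units; beyond the scatter); a 7.1-fold lower number from compound 2 to compound 4 (0.85 log units; beyond the scatter)), and both steps are beyond the scatter. This position on a nitrogen on an aromatic ring therefore does more than separate aryl-type groups from cyclopropyl: among the six-membered aromatic rings, the change from 3-chloro-4-fluorophenyl to 2-(dimethylsulfamoyl)phenyl still moves the number, and the larger sulfamoyl-bearing group costs nothing in growth inhibition. Compound 3 stands at a limit of the assay and not at a number, so the step into compound 4 (an at least 320-fold lower number from compound 3 to compound 4 (2.50 log units; beyond the scatter)) is a bound whose true size stays unknown: the limit of > 10000 nM in this assay, at which 1 of the 4 values shown sits.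

From the compounds shown here alone, whether the gain belongs to the dimethylsulfamoyl group or to the substitution pattern of the phenyl ring stays open, and an unsubstituted phenyl or a 2-(methylsulfonyl)phenyl group would separate the two. Also open, going by these compounds, is whether the two methyl groups on the sulfamoyl nitrogen matter, a question that an unsubstituted sulfonamide or a morpholine sulfonyl group on the same ring would address.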